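From Nitro to Chloro: An Expected Return Toward Stronger Inhibition

A few compounds are considered here, and "the series" means these few. Any claim that something is new, unique, unknown or untested is made for them only; others in the source may bear on it.

Compound 2 `CC(=O)c1ccc(OCc2ccccc2[N+](=O)[O-])cc1` gives the highest number of the three measured compounds in an assay on isolated protein for inhibition of Amine oxidase [flavin-containing] B (Homo sapiens), read by Amplex Red, with a stated time of 15 min (a higher number here means a weaker inhibitor, a lower number a stronger inhibitor), at 284 nM. Compound 1 `CC(=O)c1ccc(OCc2ccccc2C)cc1` gives 77.1 nM in this assay, and compound 3 `CC(=O)c1ccc(OCc2cc(F)c(F)c(F)c2)cc1` gives 84.1 nM. Compound 4 `CC(=O)c1ccc(OCc2ccccc2Cl)cc1` differs from compound 2 by chloro in place of nitro on an aromatic carbon. Among the measured compounds shown here, the only measured step that bears on this change is a 3.7-fold higher number from compound 1 to compound 2 (0.57 log units; beyond the scatter), in which a nitro group entered where a methyl group had been, at the same place as the change now considered. Removing the nitro group again in favour of a single heavy atom is therefore expected to move the number back down by a modest amount, a 3.2-fold lower number from compound 2 to compound 4 (0.50 log units; beyond the scatter). Compound 4 is estimated at 90 nM in this assay, with a range from 40 nM to 200 nM.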

Compound 4, half-maximal inhibitory concentration: 311 nM
Compound 4: the middle estimate sits 3.5-fold (0.54 log units) below what was measured, outside the stated range (above it).
By their numbers in this assay, from the lowest: compounds 1 and 3 (each within the scatter of the next); then compounds 2 and 4 (each within the scatter of the next).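

In this assay chloro in place of nitro, on an aromatic carbon ortho to a large group, leaves compound 2 and compound 4 within the scatter of each other (a 1.1-fold higher number from compound 2 to compound 4 (0.04 log units; within the scatter)). The loss seen on leaving methyl therefore does not belong to nitro alone, since chloro in place of methyl also gives a step beyond the scatter (a 4.0-fold higher number from compound 1 to compound 4 (0.61 log units; beyond the scatter)). Nothing available explains why methyl parts from both groups. On these data alone, whether an amine, a methoxy group or a carboxylic acid at this place would match methyl or chloro remains open.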